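This account rests on a few compounds, and the source may have more. Where it says the series, first, only, none or still open, it means among the compounds named here.

Measured so far in an ADME assay on liver for metabolic stability, with Liver microsome (Homo sapiens) as the target, using microsomes; a lower number here means slower removal, a higher number faster removal of the compound:
- Compound 1 `O=C(N[C@H]1CCOC[C@@H]1O)c1cn(Cc2ccc(-n3cccn3)cc2)c2cccnc12`: compound 1 gives < 8 mL/min/kg, which is a limit of the assay.
- Compound 2 `CN(C)C(=O)CNC(=O)c1cn(Cc2ccc(-n3cccn3)cc2)c2cccnc12`: compound 2 gives 9.3 mL/min/kg.
- Compound 3 `O=C(NCC1(O)CCC1)c1cn(Cc2ccc(-n3cccn3)cc2)c2cccnc12`: compound 3 gives 17 mL/min/kg.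

Compound 3 holds the highest of the two plain numbers. Yet the gap between these two plain numbers is only a 1.8-fold higher number from compound 2 to compound 3 (0.26 log units; within the scatter). Compound 1 sits at the limit of < 8 mL/min/kg in this assay, at which 1 of the 3 values shown sits, so the step of an at least 2.1-fold higher number from compound 1 to compound 3 (0.32 log units; beyond the scatter) is the only one that clearly exceeds the scatter. Compound 4 `O=C(N[C@H]1CC[C@H](CO)CC1)c1cn(Cc2ccc(-n3cccn3)cc2)c2cccnc12` carries 4-(hydroxymethyl)cyclohexyl in place of (1-hydroxycyclobutyl)methyl on an amide-type nitrogen. Both measured steps altered the same group on the amide-type nitrogen, giving changes from within the scatter to at least modest. Compound 4 is therefore expected to show a 1.4-fold lower number from compound 3 to compound 4 (0.15 log units; within the scatter). Compound 4 is estimated at 12 mL/min/kg, within 6 mL/min/kg to 24 mL/min/kg.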

Compound 4, clearance: 8.5 mL/min/kg
Beside the measured number, compound 4's estimate is 1.4-fold (0.15 log units) above it; low and high end bracket the measured number.
By their numbers in this assay, from the lowest: compounds 4, 2 and 3 (each within the scatter of the next). At a limit, below all of these: compound 1.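

In this assay, a six-membered carbon ring on the amide-type nitrogen gives a 2.0-fold lower number from compound 3 to compound 4 (0.30 log units; within the scatter) and a 1.1-fold lower number from compound 2 to compound 4 (0.04 log units; within the scatter). Both steps lie within the scatter, so the larger 4-(hydroxymethyl)cyclohexyl separates compound 4 clearly from neither compound 3 nor compound 2. The step of an at least 1.0-fold higher number from compound 1 to compound 4 (0.02 log units; that floor lies within the scatter) is only a floor, because compound 1 stands at a limit: the limit of < 8 mL/min/kg in this assay, at which 1 of the 4 values shown sits.

From the compounds shown here alone, what an amine or a carboxylic acid in place of the hydroxymethyl on the cyclohexyl ring would give remains open.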